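The source may report more compounds than this note shows. Statements on the series, on what has been measured and on what is new or still open speak of the compounds shown alone.

Measured compounds:
compound 1 `Nc1ccccc1NC(=O)/C=C/c1ccc(Cn2cnc3c(Nc4cccc(Cl)c4)nc(Cl)nc32)cc1` — in a functional assay on HepG2 cells (Homo sapiens) for antiproliferative activity, read by CCK-8 assay, with a stated time of 72 h, tested at 2 uM (on this read-out higher numbers stand for a stronger effect at the one concentration tested and lower numbers for a weaker effect), compound 1 gives 35.8%
compound 2 `Nc1ccccc1NC(=O)c1ccc(Cn2cnc3c(Nc4cccc(Cl)c4)nc(Cl)nc32)cc1` — in this assay compound 2 gives 29.9%

Of the two numbers shown, the one for compound 1 is the higher, but the only measured step, a number 5.9 percentage points lower from compound 1 to compound 2 (within the scatter), lies within the scatter, so compound 1 and compound 2 are not separated on this read-out.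

Compound 3 `Nc1ccccc1NC(=O)/C=C/c1ccc(Cn2cnc3c(NCc4ccccc4)nc(Cl)nc32)cc1` is not yet measured. It differs from compound 1 as follows: benzyl in place of 3-chlorophenyl on a nitrogen on an aromatic ring

Going by the values given here, no measured step touches this nitrogen; the single step between compound 1 and compound 2 concerns the carbamoyl-bearing linker and says nothing about the group on the ring nitrogen. There is therefore no basis in the data for a step beyond the scatter in this assay in either direction, and the expectation is taken close to compound 1 with a wide range. The step expected from the change is a number 5.8 percentage points lower from compound 1 to compound 3 (within the scatter). For compound 3 the estimated value in this assay is 30%, with a range from 10% to 55%.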

Compound 3, a percentage reported as inhibition, at one concentration (the size of the read-out at that concentration, not a potency): 11.5%
Compound 3: the middle estimate sits 18.5 percentage points above what was measured, within the range that was stated.
By their numbers in this assay, from the lowest: compound 3; then compounds 2 and 1 (each within the scatter of the next).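

In this assay, going by these compounds alone, the group on the ring nitrogen is the first place to give a step beyond the scatter: (3-chlorophenyl)amino changing to benzylamino gives a number 24.3 percentage points lower from compound 1 to compound 3 (beyond the scatter), whereas the linker change between compound 1 and compound 2 gave no such step. This single change removes the chlorine and adds a carbon link to the ring together, so the step cannot be assigned to either part. Nothing available accounts for the step.

Open, on these data alone, is which part carries the step: an unsubstituted phenyl or a 3-chlorobenzyl group on this nitrogen would separate the chlorine from the carbon link. Also open, as far as these compounds go, are a longer chain such as 2-phenylethyl and a small alkyl group such as cyclopropyl at this nitrogen.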